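One More Ring Nitrogen in the Sulfonyl Ether

The source may hold more compounds than are shown below. What is called first, only, known or untested is meant among the compounds shown, and "the series" means these compounds.

Of the compounds shown here, three built on one shared core have been measured in a functional assay on isolated protein for agonist activity at Glucose-dependent insulinotropic receptor (Rattus norvegicus), read by HTRF and cAMP accumulation; on this read-out lower numbers stand for smaller maximal responses and higher numbers for larger maximal responses. Compound 1 `CC(C)(C)OC(=O)N1CCC(O[C@H]2CC[C@@H](Oc3ccc(S(C)(=O)=O)cc3)CC2)CC1` gives 121%, and compound 2 `CC(C)(C)OC(=O)N1CCC(O[C@H]2CC[C@H](Oc3ccc(S(C)(=O)=O)cc3F)CC2)CC1` gives 119%. Compound 3 `CC(C)(C)OC(=O)N1CCC(O[C@H]2CC[C@H](Oc3ccc(S(C)(=O)=O)cn3)CC2)CC1` gives 108%, the lowest of the three numbers; its nearest neighbour is compound 2, whose number is higher by a margin beyond the usual scatter, and compound 1 stands further away still, also beyond the scatter. Compound 4 `CC(C)(C)OC(=O)N1CCC(O[C@H]2CC[C@H](Oc3ccc(S(C)(=O)=O)nn3)CC2)CC1` has not yet been measured. It differs from compound 3 in one place: 6-(methylsulfonyl)pyridazin-3-yl in place of 5-(methylsulfonyl)pyridin-2-yl on an oxygen on a saturated carbon. Within the data shown here, no pair of measured compounds that differ in only one place is available, so the expectation rests on the three numbers alone. The step from compound 3 to compound 4 is expected to be small and downward, close to the edge of the usual scatter, a number 6 percentage points lower from compound 3 to compound 4 (within the scatter). In this assay compound 4 is therefore estimated to reach 102%, within a range from 88% to 116%.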

Compound 4, largest response reached (Emax), in percent of the reference or control that the assay uses: 86%
Compound 4: the middle estimate sits 16 percentage points above what was measured, outside the stated range (below it).
By their numbers in this assay, from the lowest: compound 4; then compound 3; then compounds 2 and 1 (each within the scatter of the next).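

In this assay, among these compounds, the one comparison of compounds differing in a single place shows that this aromatic group on the ether oxygen is sensitive to a very small edit: 6-(methylsulfonyl)pyridazin-3-yl in place of 5-(methylsulfonyl)pyridin-2-yl gives a number 22 percentage points lower from compound 3 to compound 4 (beyond the scatter) in the maximal response. The two groups have the same count of heavy atoms, and the entering ring simply trades one carbon for a nitrogen, taking the count of hydrogen-bond acceptors from 3 to 4, so one ring atom is enough to produce a change beyond the usual scatter. No measurement is available that explains this drop.

From the compounds shown here alone, it remains open whether a nitrile in place of the methylsulfonyl group would respond in the same way to the extra ring nitrogen. The same question applies to a methyl amide at that point.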